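The source may report more compounds than this note shows. Statements on the series, on what has been measured and on what is new or still open speak of the compounds shown alone.

Of the compounds shown here, three of the shared core have been measured in a functional assay on MCF7 cells (Homo sapiens) for cytotoxicity, read by MTT assay, with a stated time of 72 h; on this read-out higher numbers stand for weaker inhibition and lower numbers for stronger inhibition. Compound 1 `Cc1ccc(-c2ccc([N+](=O)[O-])cc2)n1-c1ccc(-c2nc3ccccc3s2)cc1` gives 3110 nM. Compound 2 `Cc1ccc(-c2ccc(F)cc2)n1-c1ccc(-c2nc3ccc(F)cc3s2)cc1` gives 2800 nM. Compound 3 `COc1ccc(-c2ccc(C)n2-c2ccc(-c3nc4ccc(F)cc4s3)cc2)cc1` gives 2550 nM. On these numbers compound 3 stands lowest of the three, but its nearest neighbour compound 2 and its furthest neighbour compound 1 both lie within the scatter of it, so the three are treated as alike. For the measured compounds named here, the only single-point step, a 1.1-fold lower number from compound 2 to compound 3 (0.04 log units; within the scatter), is within the scatter.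

Compound 4 `Cc1ccc(-c2ccc([N+](=O)[O-])cc2)n1-c1ccc(-c2nc3ccc(F)cc3s2)cc1` is not yet measured. It differs from compound 3 by nitro in place of methoxy on an aromatic carbon. Going by the values given here, no measured pair isolates this exchange. Among the compounds with values here, compound 1 carries the same nitro group on a core that differs elsewhere and gives 3110 nM, a number within the scatter of compound 3, and the single measured step, a 1.1-fold lower number from compound 2 to compound 3 (0.04 log units; within the scatter), is also within the scatter. The expected step, a 1.1-fold higher number from compound 3 to compound 4 (0.06 log units; within the scatter), is therefore none beyond the scatter. Compound 4 is expected to give about 2900 nM in this assay, with a range from 1500 nM to 5600 nM.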

Compound 4, half-maximal inhibitory concentration: 2370 nM
The estimate for compound 4 lay 1.2-fold (0.09 log units) above the measured number; the range from low to high includes it.
By their numbers in this assay, from the lowest: compounds 4, 3, 2 and 1 (each within the scatter of the next).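

In this assay, going from 4-methoxyphenyl to 4-nitrophenyl on the fluorinated core gives no step beyond the scatter (a 1.1-fold lower number from compound 3 to compound 4 (0.03 log units; within the scatter)), and neither does nitro in place of fluoro on that same aromatic carbon (a 1.2-fold lower number from compound 2 to compound 4 (0.07 log units; within the scatter)), so fluoro, methoxy and nitro read alike at this position. The second place on the core, with nitro held fixed, is equally flat for fluoro in place of hydrogen (a 1.3-fold lower number from compound 1 to compound 4 (0.12 log units; within the scatter)). No supporting data bear on why these exchanges leave the number unmoved.

From the compounds shown here alone, whether an amine or a carboxylic acid on that aromatic carbon would move the number beyond the scatter remains open. Also open, going by these compounds, is whether a longer chain in place of the methyl would do so.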